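A few compounds are considered here, and "the series" means these few. Any claim that something is new, unique, unknown or untested is made for them only; others in the source may bear on it.

Compound 1, `Cc1cc(=O)oc2nn(C)c(C)c12`, in a functional assay on the whole organism with Mus musculus as the target, in the writhing test; a lower number here means that less compound is needed, a higher number that more compound is needed for the effect: 6.09 mg/kg.
Compound 2, `Cc1cc(=O)oc2nn(CCO)c(C)c12`, reaches the limit of this assay, > 100 mg/kg, which is a limit and not a number.

Compound 2 therefore stands at the limit of this assay, where one of the two measured values sits (the limit of > 100 mg/kg in this assay, at which 1 of the 2 values shown sits), and its true dose is known only to lie beyond that point. Compound 3, `CCCn1nc2oc(=O)cc(C)c2c1C`, differs from compound 2 by methyl in place of hydroxy on a saturated chain carbon, two bonds along the chain from an aromatic nitrogen. Among the compounds with values here, the one measured step that bears on this position is an at least 16-fold higher number from compound 1 to compound 2 (1.21 log units; beyond the scatter), the step that brought in the hydroxy group which compound 3 now loses. Undoing that change is expected to give a large step back toward lower doses in this assay, an at least 10-fold lower number from compound 2 to compound 3 (1.00 log units; beyond the scatter), though the size of the step from compound 1 to compound 2 is known only as a lower bound. Compound 3 is thus estimated at 10 mg/kg, between 3 mg/kg and 60 mg/kg.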

Compound 3, dose for half-maximal effect: 72.6 mg/kg
Estimate against measurement, compound 3: 7.3-fold (0.86 log units) below, and the stated range ends below it.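

In this assay, putting ethyl in place of hydrogen on the saturated chain carbon bound to the aromatic nitrogen gives a 12-fold higher number from compound 1 to compound 3 (1.08 log units; beyond the scatter), so the longer chain carries a large cost even without any hydroxy. The earlier pair could be read as a penalty tied to the hydroxy group, but exchanging hydroxy for methyl gives an at least 1.3-fold lower number from compound 2 to compound 3 (0.13 log units; that floor lies within the scatter), and the compounds therefore do not show that the hydroxy group accounts for the loss. That step is only a floor, set by the value of compound 2, which is a limit and not a number: the limit of > 100 mg/kg in this assay, at which 1 of the 3 values shown sits.

From the compounds shown here alone, how far compound 2 truly lies from compound 3 stays open, and with it whether the hydroxy group adds any cost of its own. The compounds shown also do not tell how an amine or a carboxylic acid in place of the hydroxy would fare.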